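A few compounds are considered here, and "the series" means these few. Any claim that something is new, unique, unknown or untested is made for them only; others in the source may bear on it.

Measured compounds:
- compound 1 `Cc1cccc(/C(N)=N/NC(=S)N2CCSCC2)n1`: 53.2%
- compound 2 `Cc1cccc(/C(N)=N/NC(=S)N2CCOCC2)n1`: 68.1%
- compound 3 `N/C(=N\NC(=S)N1CCSCC1)c1ccc(F)cn1`: 61.8%

All three values come from a functional assay on A-431 cells (Homo sapiens) for cytotoxicity, read by MTT assay, with a stated time of 72 h, tested at 10 uM; a higher number here means more inhibition of growth at the concentration tested, a lower number less inhibition of growth. Compound 1 and compound 2 share a core and differ in one place: morpholin-4-yl in place of thiomorpholin-4-yl on a thiocarbonyl carbon. This change gives a number 14.9 percentage points higher from compound 1 to compound 2 (beyond the scatter). Compound 3 carries a different core; how it differs from the core of compound 1 is not broken down here. Among the measured compounds shown here, its value lies within the scatter of compound 2 and within the scatter of compound 1, so no order among the three is claimed beyond the single step from compound 1 to compound 2.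

Compound 4 `N/C(=N\NC(=S)N1CCOCC1)c1ccc(F)cn1` has not yet been measured in this assay. It stands to compound 3 as compound 2 stands to compound 1: morpholin-4-yl in place of thiomorpholin-4-yl on a thiocarbonyl carbon. The place is the same in both pairs, a thiocarbonyl carbon whose other neighbour is an amide-type nitrogen, so this is the same change made a second time, now on the core of compound 3.

For the measured compounds named here, the only guide to its size is the one measured step from compound 1 to compound 2. On that basis compound 4 is expected to move by about a number 11.2 percentage points higher from compound 3 to compound 4 (beyond the scatter) from compound 3, because the earlier step gave a number 14.9 percentage points higher from compound 1 to compound 2 (beyond the scatter). Since one step is a thin basis and the starting values of compound 1 and compound 3 lie within scatter of each other, the range is kept wide. The estimate for compound 4 in this assay is 73%, expected between 58% and 86%.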

Compound 4, percent growth inhibition at one concentration: 66.9%
For compound 4 the middle estimate is 6.1 percentage points above the measured one, within the range that was stated.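

In this assay, morpholin-4-yl in place of thiomorpholin-4-yl on a thiocarbonyl carbon, now on the core of compound 3, gives a number 5.1 percentage points higher from compound 3 to compound 4 (within the scatter). Set beside the step on the core of compound 1, this step cannot be told apart from it: the same change on two cores in this assay, a number 14.9 percentage points higher (beyond the scatter) from compound 1 to compound 2 and a number 5.1 percentage points higher (within the scatter) from compound 3 to compound 4, 9.8 percentage points apart, within the scatter of two such steps. Among the compounds shown here, the pairs therefore show no dependence of this change on the core, but they do not show that the step beyond the scatter carries over either, since the second step alone establishes no difference within its pair, and two pairs are too few to support a rule for the series.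

Open, as far as these compounds go, is whether other groups on the same thiocarbonyl carbon, such as piperidin-1-yl, a piperazine ring or an open-chain dimethylamino group, would give steps that separate the two cores more clearly than this exchange of sulfur for oxygen in the ring. Also open, from the compounds shown here alone, is whether a full concentration series on these four compounds, rather than readings at one tested concentration, would separate the two steps or leave them as close as they stand here.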